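The source may report more compounds than this note shows. Statements on the series, on what has been measured and on what is new or still open speak of the compounds shown alone.

Measured in an ADME assay on L02 cells (Homo sapiens) for cytotoxicity, read by MTT assay, with a stated time of 24 h; a lower number here means a stronger inhibitor, a higher number a weaker inhibitor:

- compound 1 `COc1cc(/C=C2\CN(C)C/C(=C\c3cccnc3)C2=O)cc(OC)c1`: 18400 nM
- compound 2 `COc1cc(/C=C2\CN(C)C/C(=C\c3ccncc3)C2=O)cc(OC)c1`: 13400 nM
- compound 3 `O=C1/C(=C/c2cccnc2)CN(S(=O)(=O)c2ccccc2)C/C1=C\c1ccccc1F`: 15300 nM

At 15300 nM, compound 3 lies within the scatter of both other compounds, so the three values form a single group in this assay. The next compound, compound 4 `O=C1/C(=C/c2cccnc2)CN(S(=O)(=O)c2ccc(F)cc2)C/C1=C\c1ccccc1F`, departs from compound 3 by one substitution: fluoro in place of hydrogen on an aromatic carbon. This turns phenylsulfonyl into (4-fluorophenyl)sulfonyl.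

Among the compounds with values here, only one step between measured compounds is available, a 1.4-fold lower number from compound 1 to compound 2 (0.14 log units; within the scatter). It is within the scatter, but it exchanges pyridin-3-yl for pyridin-4-yl and so bears only indirectly on this change. Within the data shown here, no measured pair tests the fluoro substitution itself. A shift beyond the scatter is therefore not expected in this assay, and no direction is favoured with any confidence.

The expected change is a 1.1-fold lower number from compound 3 to compound 4 (0.05 log units; within the scatter). Compound 4 is estimated at 13500 nM, with an expected range from 7000 nM to 25000 nM.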

Compound 4, half-maximal inhibitory concentration: 15600 nM
Estimate against measurement, compound 4: 1.2-fold (0.06 log units) below, and the stated range covers the measured number.
By their numbers in this assay, from the lowest: compounds 2, 3, 4 and 1 (each within the scatter of the next).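

In this assay, the exchange of phenylsulfonyl for (4-fluorophenyl)sulfonyl gives a 1.0-fold higher number from compound 3 to compound 4 (0.01 log units; within the scatter), the only step shown that tests a substitution on this ring. A fluoro para to a large group therefore leaves the number within the scatter here, whereas the earlier step concerned only the pyridinyl group and could say nothing directly about this position. No measured evidence is available to explain this result.

From the compounds shown here alone, it remains open whether a larger or charged group at the same carbon, such as methoxy, an amine or a carboxylic acid, would move the number beyond the scatter. Going by these compounds, it also remains open whether fluoro on another carbon of this ring would leave the number similarly unchanged.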